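The source may hold more compounds than are shown below. What is called first, only, known or untested is meant among the compounds shown, and "the series" means these compounds.

Series notes, continued.

Within the data shown here, the two measured members share one core. Compound 1 `O=C(c1ccc(-c2ccc3c(c2)CNC3)s1)N1N=C(c2cccnc2)CC1c1ccccc1O` carries hydrogen at the position in question; in an in vivo ADME assay on the whole organism (strain Sprague-Dawley) for pharmacokinetics, with Rattus norvegicus as the target (on this read-out higher numbers stand for fast clearance and lower numbers for slow clearance), compound 1 gives 58.3 mL/min/kg. Compound 2 `O=C(c1ccc(-c2ccc3c(c2)CNC3)s1)N1N=C(c2cccnc2)CC1c1c(O)cccc1F` carries fluoro there instead, and in this assay compound 2 gives 15 mL/min/kg. Among the measured compounds shown here, the only step measured so far is a 3.9-fold lower number from compound 1 to compound 2 (0.59 log units; beyond the scatter), so compound 2 stands at the lowest of the two numbers in hand, with compound 1 the nearest and higher.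

Compound 3 `O=C(c1ccc(-c2cccc3c2CCNC3)s1)N1N=C(c2cccnc2)CC1c1c(O)cccc1F` is the next member to be run. Relative to compound 2 the change is a group of 10 heavy atoms (9 carbon, 1 nitrogen; one six-membered non-aromatic ring with 1 hetero atom, one six-membered aromatic ring of carbon only) in place of a group of 9 heavy atoms (8 carbon, 1 nitrogen; one five-membered non-aromatic ring with 1 hetero atom, one six-membered aromatic ring of carbon only), on an aromatic carbon; the fluoro and the rest of the molecule are kept. For the measured compounds named here, no measured step bears directly on this change: the single step in hand, fluoro in place of hydrogen from compound 1 to compound 2, touches a different position and a different kind of group, so it gives no guide to the size or direction of the change in hand. For compound 3 the expected step is therefore no change at the digits printed from compound 2 to compound 3 (within the scatter). On that basis the expected reading for compound 3 in this assay is 15 mL/min/kg, with a range from 7 mL/min/kg to 35 mL/min/kg.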

Compound 3, clearance: 11.7 mL/min/kg
Estimate against measurement, compound 3: 1.3-fold (0.11 log units) above; measured number inside the range.
By their numbers in this assay, from the lowest: compounds 3 and 2 (each within the scatter of the next); then compound 1.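

In this assay, 1,2,3,4-tetrahydroisoquinolin-5-yl in place of the group in compound 2, on the aromatic carbon next to the ring sulfur, gives a 1.3-fold lower number from compound 2 to compound 3 (0.11 log units; within the scatter). The earlier pair spoke only to the fluoro position; this step adds that, with fluoro present, going from a five-membered to a six-membered non-aromatic ring at this second position leaves the clearance reading within the scatter, with compound 3 at 11.7 mL/min/kg. Nothing in hand accounts for this reading or bears on what lies behind it.

Still open, on these data alone, is how much change this position accepts, since both groups compared are fused bicyclic amines with one ring nitrogen; a phenyl ring carrying an open-chain aminomethyl group, or a methyl group on the ring nitrogen of 1,2,3,4-tetrahydroisoquinolin-5-yl, would test this more sharply. Also open is whether the fluoro step carries over, as the compounds shown include no partner of compound 3 with hydrogen in place of fluoro.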